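This account rests on a few compounds, and the source may have more. Where it says the series, first, only, none or still open, it means among the compounds named here.

In a functional assay on RAW264.7 cells (Mus musculus) for inhibition, read by ELISA, with a stated time of 24 h (a higher number here means that more compound is needed for the effect, a lower number that less compound is needed), compound 1 (`CC/C=C\C[C@H]1C(=O)C=C[C@H]1CC(=O)OCc1ccccc1`) gives 20000 nM and compound 2 (`CC/C=C\C[C@H]1C(=O)C=C[C@H]1CC(=O)Oc1ccc(O)cc1`) gives 23000 nM and these two values stand within the scatter of each other, so neither compound stands apart. Compound 3 (`CC/C=C\C[C@H]1C(=O)C=C[C@H]1CC(=O)OCCO`) has not yet been measured. The change from compound 2 puts 2-hydroxyethyl in place of 4-hydroxyphenyl on an oxygen next to a carbonyl group. Within the data shown here, the one measured step at this place is a 1.2-fold higher number from compound 1 to compound 2 (0.06 log units; within the scatter) and it replaced benzyl with 4-hydroxyphenyl. That step exchanged one group holding a six-membered aromatic ring for another, whereas the group entering compound 3 has no ring, so the evidence is only indirect. Among the measured compounds shown here, no measured compound yet lacks a ring at this place. With compound 2 at 23000 nM as the anchor, no step beyond the scatter is expected in this assay and no direction can be assigned. The estimated change is a 1.0-fold lower number from compound 2 to compound 3 (0.02 log units; within the scatter) and it is expected to stay within the scatter. Compound 3 is estimated at 22000 nM with an expected range from 10000 nM to 50000 nM in this assay as the working figure.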

Compound 3, half-maximal effective concentration: 24000 nM
For compound 3 the middle estimate is 1.1-fold (0.04 log units) below the measured one; the range from low to high includes it.
By their numbers in this assay, from the lowest: compounds 1, 2 and 3 (each within the scatter of the next).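

At the place on an oxygen next to a carbonyl group, this assay now covers a group with no ring: 2-hydroxyethyl in place of 4-hydroxyphenyl gives a 1.0-fold higher number from compound 2 to compound 3 (0.02 log units; within the scatter), and hydroxymethyl in place of phenyl on a saturated chain carbon bound to that oxygen gives a 1.2-fold higher number from compound 1 to compound 3 (0.08 log units; within the scatter). Both steps lie within the scatter, so the loss of the six-membered aromatic ring present in compound 1 and compound 2 produces no measurable shift, and compound 3 at 24000 nM cannot be separated from either of them. No measured information is available to explain this flat result.

The compounds shown leave open whether any group at this place can move the number beyond the scatter, as all three groups tested here are neutral and none is an amine, a carboxylic acid or a longer alkyl chain. They also leave open how the shared core contributes to this level of activity, as every compound here carries that core unchanged.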